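The source may report more compounds than this note shows. Statements on the series, on what has been measured and on what is new or still open speak of the compounds shown alone.

Measured compounds:
Compound 1 `CCCCN(CC)c1cc(C)nc2c1NC(=O)CN2c1ccc(C)cc1Cl` — "not determined" (no result reported) in an assay on HEK-293T cells for displacement of a labelled ligand from corticotropin-releasing factor receptor 2 (Homo sapiens), read by scintillation counting, with a stated time of 2 h, tested at 1 uM; a lower number here means less inhibition, a higher number more inhibition at the concentration tested (going by the name of the read-out) (no result reported).
Compound 2 `CCCCN(CC)c1cc(C)nc2c1NC(=O)CN2c1ccc(Br)cc1Br` — 9.4% in this assay.
Compound 3 `CCCCN(CC)c1cc(C)nc2c1NC(=O)CN2c1ccc(Br)cc1CC` — 2.1% in this assay.

Where compound 2 stands: of the two numbers shown, compound 2 and compound 3 lie within the scatter of each other, as the step of a number 7.3 percentage points lower from compound 2 to compound 3 (within the scatter) shows, and the third entry, compound 1, carries no number at all. Both measured numbers are small, so neither compound displaces much of the labelled ligand at the concentration tested.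

The unmeasured compound is compound 4 `CCCCN(CC)c1cc(C)nc2c1NC(=O)CN2c1ccc(C)cc1Br`. It differs from compound 2 by methyl in place of bromo on an aromatic carbon. For the measured compounds named here, the only measured step that bears on this change is the one from compound 2 to compound 3, which also replaced a bromo on an aromatic carbon of the same ring with a small alkyl group, and that step stayed within the scatter. On this evidence the exchange of a bromo for a methyl is expected to leave the readout in this assay essentially where compound 2 stands, with no step beyond the scatter in either direction.

Compound 4 is therefore estimated to give 7% in this assay, within a range from 0% to 20%, an expected step of a number 2.4 percentage points lower from compound 2 to compound 4 (within the scatter).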

Compound 4, a percentage reported as inhibition, at one concentration (the size of the read-out at that concentration, not a potency): 5.5%
For compound 4 the middle estimate is 1.5 percentage points above the measured one, within the range that was stated.
By their numbers in this assay, from the lowest: compounds 3, 4 and 2 (each within the scatter of the next).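

Read in this assay, the change from 2,4-dibromophenyl to 2-bromo-4-methylphenyl gives a number 3.9 percentage points lower from compound 2 to compound 4 (within the scatter) and so shows something the earlier pair did not: the earlier step altered the other bromo, whereas this one places methyl in place of bromo on the aromatic carbon para to a large group, and the read-out again stays within the scatter. The new compound also links to the ethyl compound, with a number 3.4 percentage points higher from compound 3 to compound 4 (within the scatter) for 2-bromo-4-methylphenyl in place of 4-bromo-2-ethylphenyl, so the three numbers cannot be put in any firm order and neither bromo exchange shown here separates from the others. Nothing at hand offers an explanation for these numbers.

Where compound 4 carries a bromo group, compound 1 carries a chloro group and gives "not determined" (no result reported) in this read-out, so that exchange cannot be judged and its step cannot be read. Going by these compounds, it also stays open whether a larger or differently built group at the para carbon, such as an amine, a carboxylic acid or a longer alkyl chain, would move the number beyond the scatter.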